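A dithiocarbamate swap on a chromone core

The source may hold more compounds than are shown below. What is called first, only, known or untested is meant among the compounds shown, and "the series" means these compounds.

Compound 1 `COc1ccc2occ(CSC(=S)N(C(C)C)C(C)C)c(=O)c2c1` carries a diisopropylamino group on a thiocarbonyl carbon that is joined to the rest of the molecule through sulfur. In a functional assay on HEp-2 cells (Homo sapiens) for antiproliferative activity, read by MTT assay, with a stated time of 72 h (on this read-out lower numbers stand for stronger inhibition and higher numbers for weaker inhibition), compound 1 gives 8900 nM. Among the measured compounds shown here, this is the only outright number in the set: compound 2 `O=c1cc(CSC(=S)N2CCCC2)oc2cc(Cl)ccc12`, with a different core and a pyrrolidine on the thiocarbonyl carbon, is reported in this assay only as a limit, > 40000 nM, so no number is known for it (the limit of > 40000 nM in this assay, at which 1 of the 2 values shown sits). Compound 3 `COc1ccc2occ(CSC(=S)N3CCOCC3)c(=O)c2c1` keeps the core of compound 1 and differs in one place: morpholin-4-yl in place of diisopropylamino on a thiocarbonyl carbon. For the measured compounds named here, with no measured step of this kind to lean on, the move from compound 1 to compound 3 is expected to be a modest weakening, a 1.7-fold higher number from compound 1 to compound 3 (0.23 log units; within the scatter), possibly no larger than the scatter. Compound 3 is therefore estimated at 15000 nM in this assay, with a range from 5000 nM to 45000 nM.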

Compound 3, half-maximal inhibitory concentration: 4800 nM
For compound 3 the middle estimate is 3.1-fold (0.49 log units) above the measured one; the measured number lies below the stated range.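

In this assay, putting morpholin-4-yl on the thiocarbonyl carbon gives a 1.9-fold lower number from compound 1 to compound 3 (0.27 log units; within the scatter), so the two compounds cannot be told apart. At this one place on the core of compound 1, then, an open, branched diisopropylamino group and a six-membered non-aromatic ring holding an oxygen give values that agree within the usual scatter of the measurement. Nothing shown bears on why the two values lie so close.

Still open, from the compounds shown here alone, is whether the ring and its oxygen matter separately: a piperidine at the same place, on the same core, would pull the two apart. A piperazine, with its second ring amine, or a longer chain such as di-n-butylamino, would show how far this place accepts other groups.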